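Acetoxy to benzoyloxy on the compound 2 scaffold

The compounds below may be only part of what the source reports. "The series", "measured", "known", "first", "only" and "open" are said of these compounds alone.

Measured in a functional assay on MCF7 cells (Homo sapiens) for inhibition, read by MTT assay, with a stated time of 72 h, tested at 30 ug/mL; a lower number here means less inhibition of growth, a higher number more inhibition of growth at the concentration tested:
- compound 1 `C=C1[C@H](OCC(C)C)C[C@@H](OC(=O)c2cccnc2)C(C)(C)/C=C/[C@@H](C)C(=O)[C@@]2(OC(C)=O)C[C@H](C)[C@H](OC(C)=O)[C@@H]2[C@H]1OC(C)=O`: 14.4%
- compound 2 `C=C1[C@H](OC(C)=O)CC(=O)C(C)(C)/C=C/[C@@H](C)C(=O)[C@@]2(OC(C)=O)C[C@@](C)(OC(C)=O)[C@H](OC(C)=O)[C@@H]2[C@H]1OC(C)=O`: 43.3%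

Compound 2 stands higher of the two, beyond the scatter from compound 1. Compound 3 `C=C1[C@H](OC(C)=O)CC(=O)C(C)(C)/C=C/[C@@H](C)C(=O)[C@@]2(OC(C)=O)C[C@@](C)(OC(=O)c3ccccc3)[C@H](OC(C)=O)[C@@H]2[C@H]1OC(C)=O` differs from compound 2 in one place: phenyl in place of methyl on a carbonyl carbon. This is phenyl in place of methyl on a carbonyl carbon, acetoxy to benzoyloxy. Among the compounds with values here, no measured pair isolates this change, and compound 1 differs from compound 2 in several places, so the expectation is weakly founded. A small downward move, within the scatter, is expected in this assay. The expected step is a number 5.3 percentage points lower from compound 2 to compound 3 (within the scatter). For compound 3 the estimate is 38%, with an expected range of 18% to 58%.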

Compound 3, percent growth inhibition at one concentration: 60.1%
The estimate for compound 3 lay 22.1 percentage points below the measured number, outside the stated range (above it).
By their numbers in this assay, from the lowest: compound 1; then compound 2; then compound 3.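

In this assay the change of acetoxy to benzoyloxy gives a number 16.8 percentage points higher from compound 2 to compound 3 (beyond the scatter) and is the only single-place step among these compounds. It shows that this position accepts phenyl in place of methyl on a carbonyl carbon, with more growth inhibition at the concentration tested. Nothing available bears on the reason for this step.

As far as these compounds go, whether the gain requires the aromatic ring or only a larger acyl group stays open, and a cyclohexanecarbonyl or hexanoyl ester here would separate the two. An amine on the phenyl ring also remains untested in the compounds shown.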